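A few compounds are considered here, and "the series" means these few. Any claim that something is new, unique, unknown or untested is made for them only; others in the source may bear on it.

Compound 1 `O=C(Nc1cccc(-n2cc(-c3ccncc3)c(-c3ccc(Cl)c(O)c3)n2)c1)Nc1ccc(Cl)c(Cl)c1` is the starting point here. In a functional assay on NCI-H522 cells (Homo sapiens) for inhibition, read by sulforhodamine B assay, with a stated time of 48 h (on this read-out lower numbers stand for higher toxicity in this test and higher numbers for lower toxicity in this test), compound 1 gives only the limit > 32500 nM, so no number is known for it; this is a limit of the measurement, not a value. Two related compounds are also on record. Compound 2 `COc1cc(-c2nn(-c3cccc(NC(=O)Nc4cccc(C(F)(F)F)c4)c3)cc2-c2ccncc2)ccc1Cl` reaches only the limit > 50000 nM in this assay. Compound 3 `COc1cc(-c2nn(-c3cccc(NC(=O)Nc4ccc(Cl)c(C(F)(F)F)c4)c3)cc2-c2ccncc2)ccc1Cl` likewise reaches only the limit > 32500 nM in this assay. Among the measured compounds shown here, the one measured step between them, a step that the two limits leave unreadable from compound 2 to compound 3, cannot be read because both ends are limits the limit of > 32500 nM in this assay, at which 2 of the 3 values shown sit (the limit of > 50000 nM in this assay, at which 1 of the 3 values shown sits).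

Compound 4 `COc1cc(-c2nn(-c3cccc(NC(=O)Nc4ccc(Cl)c(Cl)c4)c3)cc2-c2ccncc2)ccc1Cl` differs from compound 1 by methyl in place of hydrogen on an oxygen on an aromatic ring. For the measured compounds named here, no measured step follows this hydroxy to methoxy change, so its size cannot be taken from the data. Compounds 2 and 3 already carry the 4-chloro-3-methoxyphenyl group and sit at limits, which gives no hint of a reading appearing in this assay. Compound 4 is therefore expected to show 50000 nM, likely as a limit, within 32500 nM to 120000 nM, and the expected step is a step that the limit leaves unreadable from compound 1 to compound 4.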

Compound 4, concentration lethal to 50% of the cells: > 50000 nM
Compound 4: no number, only a limit (the forecaster's own chance of this, stated with the estimate: 85%); the middle value sits exactly at the limit.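

Compound 4, like compound 1, compound 2 and compound 3, gives only a limit in this assay, and none of its steps from these compounds can be read. The compounds shown leave open what lethal concentration any of them actually has, and how far the change from hydroxy to methoxy moves it.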